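Swapping Difluorophenyl for Nitrophenyl on the Amide Carbonyl

The compounds below may be only part of what the source reports. "The series", "measured", "known", "first", "only" and "open" are said of these compounds alone.

Measured so far in an assay on microsomes from liver for inhibition of sterol O-acyltransferase 1 (Rattus norvegicus); on this read-out higher numbers stand for weaker inhibition and lower numbers for stronger inhibition:
compound 1, `CCCCCCCCCCCCn1nnc(C(NC(=O)c2c(C)cccc2C)c2ccccc2)n1`, gives 310 nM
compound 2, `CCCCCCCCCCCCn1nnc(C(NC(=O)c2ccc(F)cc2F)c2ccccc2)n1`, gives 490 nM
compound 3, `CCCCCCCCCCCCn1nnc(C(NC(=O)c2cccc(Cl)c2)c2ccccc2)n1`, gives 250 nM

Compound 2 carries the highest of the three numbers, yet its nearest neighbour is compound 1 at a 1.6-fold higher number from compound 1 to compound 2 (0.20 log units; within the scatter) and its furthest is compound 3 at a 2.0-fold lower number from compound 2 to compound 3 (0.29 log units; within the scatter), both within the scatter, so the three compounds cannot be told apart on these data.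

Compound 4, `CCCCCCCCCCCCn1nnc(C(NC(=O)c2cccc([N+](=O)[O-])c2)c2ccccc2)n1`, differs from compound 2 as follows: 3-nitrophenyl in place of 2,4-difluorophenyl on a carbonyl carbon. The comparison that bears most directly on this is the move from compound 2 to compound 3, where another substituted phenyl took the place of the same 2,4-difluorophenyl and the number shifted by a 2.0-fold lower number from compound 2 to compound 3 (0.29 log units; within the scatter). The move from compound 1 to compound 2 was a 1.6-fold higher number from compound 1 to compound 2 (0.20 log units; within the scatter). Every aryl group tried on this carbonyl has so far landed within the scatter of the others, and nothing in the data points to the 3-nitrophenyl behaving differently. The expected step is therefore a 1.5-fold lower number from compound 2 to compound 4 (0.19 log units; within the scatter), no more than scatter. Compound 4 is thus estimated at 320 nM, within a range from 120 nM to 850 nM.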

Compound 4, half-maximal inhibitory concentration: 80 nM
Compound 4: the middle estimate sits 4.0-fold (0.60 log units) above what was measured; the measured number lies below the stated range.
By their numbers in this assay, from the lowest: compound 4; then compounds 3, 1 and 2 (each within the scatter of the next).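

Read in this assay this carbonyl position now shows, for the first time, a difference beyond the scatter, with a 6.1-fold lower number from compound 2 to compound 4 (0.79 log units; beyond the scatter) when 3-nitrophenyl replaces 2,4-difluorophenyl and a 3.9-fold lower number from compound 1 to compound 4 (0.59 log units; beyond the scatter) when it replaces 2,6-dimethylphenyl. For the compounds shown here, the closest comparison is the single swap of nitro in place of chloro on an aromatic carbon, which gives a 3.1-fold lower number from compound 3 to compound 4 (0.49 log units; beyond the scatter) on the shared core. Compound 4 is therefore the strongest inhibitor of the four, and among these aryl groups only 3-nitrophenyl stands apart from the rest.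

Going by these compounds, whether a nitrile, a carboxylic acid or an amine in place of the nitro would keep or lose this lower number remains open. Nothing shown offers a measured explanation for the difference.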